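A few compounds are considered here, and "the series" means these few. Any claim that something is new, unique, unknown or untested is made for them only; others in the source may bear on it.

Compound 1: `Nc1nc(N/N=C/c2cccc(OCc3ccccc3)c2)nc2c1ncn2[C@@H]1O[C@H](CO)[C@@H](O)[C@H]1O` gives 13 nM
Compound 2: `Nc1nc(N/N=C/c2ccc3ncccc3c2)nc2c1ncn2[C@@H]1O[C@H](CO)[C@@H](O)[C@H]1O` gives 9.8 nM
Compound 3: `Nc1nc(N/N=C/c2ccc(-c3ccccn3)cc2)nc2c1ncn2[C@@H]1O[C@H](CO)[C@@H](O)[C@H]1O` gives 7540 nM

These three compounds share one core and differ only in the group attached to a carbon with a double bond to nitrogen. In an assay on CHO-K1 cells for displacement of a labelled ligand from adenosine receptor A1 (Homo sapiens), read by scintillation counting, with a stated time of 60 min (a higher number here means a weaker inhibitor, a lower number a stronger inhibitor), compound 2 gives 9.8 nM, the lowest of the three numbers. Compound 1 gives 13 nM, which sits within the usual scatter of the value for compound 2, so the two cannot be told apart. Compound 3 gives 7540 nM, a much weaker result that lies well beyond the scatter.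

Compound 4, `Nc1nc(N/N=C/c2cccnc2Cl)nc2c1ncn2[C@@H]1O[C@H](CO)[C@@H](O)[C@H]1O`, has not yet been measured in this assay. The change from compound 2 is 2-chloropyridin-3-yl in place of quinolin-6-yl on a carbon with a double bond to nitrogen. Within the data shown here, no measured pair isolates a change of this kind, so the expectation rests only on the spread seen so far: two of the three groups give values close to each other, while the third costs a great deal of binding. A loss beyond the scatter is expected, but one far smaller than that seen for compound 3. Compound 4 is estimated at 40 nM in this assay, with a range from 8 nM to 250 nM. The expected step of a 4.1-fold higher number from compound 2 to compound 4 (0.61 log units; beyond the scatter) is a moderate weakening.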

Compound 4, inhibition constant: 4.6 nM
Compound 4: middle estimate off by 8.7-fold (0.94 log units), on the high side; the measured number lies below the stated range.
By their numbers in this assay, from the lowest: compound 4; then compounds 2 and 1 (each within the scatter of the next); then compound 3.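

In this assay, swapping quinolin-6-yl for 2-chloropyridin-3-yl gives a 2.1-fold lower number from compound 2 to compound 4 (0.33 log units; beyond the scatter), so the modest change runs towards stronger binding even though the entering group has one ring instead of two and fewer heavy atoms. Before this result, the low numbers belonged to compound 1 and compound 2, which both carry two aromatic rings in this part of the molecule, but compound 4 shows that a second ring is not required for a low number at this position, and compound 3, also with two rings, gives 7540 nM, so the ring count alone does not set the value. Nothing measured here explains why the number falls, and this single step cannot establish a trend with size.

This one change alters several things at once, so the compounds shown do not separate the role of the chlorine from that of the ring itself or the place of its nitrogen. A plain pyridin-3-yl group without the chlorine, or a 2-chlorophenyl group without the ring nitrogen, would pull those contributions apart.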